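A few compounds are considered here, and "the series" means these few. Any claim that something is new, unique, unknown or untested is made for them only; others in the source may bear on it.

Notes on the series in an ADME assay on Vero cells (Chlorocebus sabaeus) for cytotoxicity, read by neutral red uptake, tested at 1575 ug/mL; a lower number here means a stronger effect, a higher number a weaker effect of the compound at the concentration tested.

Compound 3 `O=C1CSC(c2ccc(F)cc2)N1CCN1CCCCC1` gives 14% in this assay. Compound 1 `O=C1CSC(c2cccc(Cl)c2)N1CCN1CCCCC1` gives 20%, and compound 2 `O=C1CSC(c2cccc(O)c2)N1CCN1CCCCC1` gives 13%; compound 3 lies within the scatter of both, so none of the three can be set apart from the others on the numbers shown.

Compound 4 `O=C1CSC(c2cccc(F)c2)N1CCN1CCCCC1` is not yet measured. Its change from compound 3 is 3-fluorophenyl in place of 4-fluorophenyl on a saturated ring carbon.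

The measured steps that touch the same ring carbon are a number 6 percentage points lower from compound 1 to compound 3 (within the scatter) and a number 1 percentage points higher from compound 2 to compound 3 (within the scatter); both are within the scatter, and each also exchanged the substituent, not only its position, so neither isolates a move of fluorine on the phenyl ring. Within the data shown here, no step isolates that move. With every measured step within the scatter, the expected step is a number 2 percentage points higher from compound 3 to compound 4 (within the scatter), not beyond the scatter in either direction.

For compound 4 the estimated value in this assay is 16%, expected to fall between 6% and 28%.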

Compound 4, a percentage reported as activity, at one concentration (the size of the read-out at that concentration, not a potency): 17%
Compound 4: middle estimate off by 1 percentage points, on the low side; the range from low to high includes it.
By their numbers in this assay, from the lowest: compounds 2, 3, 4 and 1 (each within the scatter of the next).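

3-fluorophenyl in place of 4-fluorophenyl on the saturated ring carbon is the first step in the series that changes only where the fluorine sits, and in this assay it gives a number 3 percentage points higher from compound 3 to compound 4 (within the scatter), so these two placements cannot be told apart. On the same aromatic carbon, fluoro in place of chloro gives a number 3 percentage points lower from compound 1 to compound 4 (within the scatter) and fluoro in place of hydroxy gives a number 4 percentage points higher from compound 2 to compound 4 (within the scatter), so chloro, hydroxy and fluoro at that place cannot be told apart either. Nothing available on these compounds offers an explanation for these numbers.

Open, going by these compounds, is whether a group of another kind on that aromatic carbon, such as a carboxylic acid, a dimethylamino group or a longer chain like butoxy, would give a step beyond the scatter. Also open, on these data alone, is whether the compounds would stay this close at other concentrations, since one tested concentration gives the size of the read-out and not a potency.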